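Half-life on aorta: methyl to isopropyl ester

The source may hold more compounds than are shown below. What is called first, only, known or untested is meant among the compounds shown, and "the series" means these compounds.

Of the compounds shown here, two from this series have been measured in a functional assay on aorta with Voltage-dependent L-type calcium channel subunit alpha-1C (Oryctolagus cuniculus) as the target; a lower number here means that the compound disappears faster, a higher number that the compound lasts longer. Compound 1 `CC1=NC(C)=C(C(=O)OCCCN2C(=O)c3ccccc3S2(=O)=O)C(c2ccccc2[N+](=O)[O-])/C1=C(\O)OC(C)C` gives 0.145 h. Compound 2 `CO/C(O)=C1\C(C)=NC(C)=C(C(=O)OCCCN2C(=O)c3ccccc3S2(=O)=O)C1c1cccc(Cl)c1Cl` gives 0.283 h, the higher of the two numbers, though compound 1 stands within the usual scatter of it, so no order between them can be claimed.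

Compound 3 `CC1=NC(C)=C(C(=O)OCCCN2C(=O)c3ccccc3S2(=O)=O)C(c2cccc(Cl)c2Cl)/C1=C(\O)OC(C)C` has not yet been measured. It differs from compound 2 in one place: isopropyl in place of methyl on an oxygen on an unsaturated carbon, in words, isopropyl in place of methyl on an oxygen on an unsaturated carbon. Going by the values given here, no measured pair in this set shows this change on its own, so the size of the step can only be guessed. Compound 1 carries the same isopropyl ester on a different core and gives 0.145 h, a number within the scatter of compound 2, which gives no sign of a large move in either direction.

Compound 3 is therefore expected to give about 0.25 h in this assay, with a range from 0.12 h to 0.5 h. The expected step of a 1.1-fold lower number from compound 2 to compound 3 (0.05 log units; within the scatter) is estimated to stay within the scatter.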

Compound 3, half-life: 0.185 h
Beside the measured number, compound 3's estimate is 1.4-fold (0.13 log units) above it; the range from low to high includes it.
By their numbers in this assay, from the lowest: compounds 1, 3 and 2 (each within the scatter of the next).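

In this assay, going by these compounds alone, the exchange of methoxy to isopropoxy, on an oxygen on an unsaturated carbon, can now be read on its own for the first time: it is a 1.5-fold lower number from compound 2 to compound 3 (0.18 log units; within the scatter), so at this position, on this core, the half-life does not respond to the change by more than repeated measurements would vary. Within the data shown here, the isopropyl ester also gives the first clean reading of the other place, where 2,3-dichlorophenyl in place of 2-nitrophenyl on a saturated ring carbon is a 1.3-fold higher number from compound 1 to compound 3 (0.11 log units; within the scatter), and this too cannot be told apart from the scatter. Nothing available explains why either change leaves the number where it is.

From the compounds shown here alone, each of these changes rests on a single pair, so it remains open whether a benzyl group or a longer chain ending in an amine on the same oxygen would move the half-life beyond the scatter. Going by these compounds, it is equally open whether a 3-cyanophenyl group on that saturated ring carbon would do so.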